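The source may report more compounds than this note shows. Statements on the series, on what has been measured and on what is new or still open speak of the compounds shown alone.

Compound 1 `Cc1nc(N(C)C(=O)NC(=O)c2c(F)cccc2F)sc1C(=O)N/N=C/c1ccccc1C(F)(F)F`: 1.11 ug/mL
Compound 2 `CN(C(=O)NC(=O)c1cccc(C(F)(F)F)c1)c1nc(C(F)(F)F)c(C(=O)N/N=C/c2ccccc2C(F)(F)F)s1`: 10.4 ug/mL
Compound 3 `CN(C(=O)NC(=O)c1cccc([N+](=O)[O-])c1)c1nc(C(F)(F)F)c(C(=O)N/N=C/c2ccccc2C(F)(F)F)s1`: 4.8 ug/mL

All three were tested in a functional assay on HepG2 cells (Homo sapiens) for inhibition, read by MTT assay, with a stated time of 72 h; a higher number here means a weaker inhibitor, a lower number a stronger inhibitor. Among these three numbers compound 3 stands second highest with 4.8 ug/mL; compound 2 lies closest to it with 10.4 ug/mL, and compound 1 lies furthest with 1.11 ug/mL.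

Compound 4 `CN(C(=O)NC(=O)c1c(F)cccc1F)c1nc(C(F)(F)F)c(C(=O)N/N=C/c2ccccc2C(F)(F)F)s1` has not yet been measured. It differs from compound 3 in a single place: 2,6-difluorophenyl in place of 3-nitrophenyl on a carbonyl carbon.

Going by the values given here, only one measured step alters the group on that same carbonyl carbon: a 2.2-fold lower number from compound 2 to compound 3 (0.34 log units; beyond the scatter). That step was modest in size. Among the compounds with values here, compound 1 carries the same 2,6-difluorophenyl group that enters in compound 4, but on a different core, and no single-change step connects it to compound 3; it can only be noted that compound 1 gives 1.11 ug/mL while compound 3 gives 4.8 ug/mL. On this basis a step to a lower number is expected for compound 4 in this assay, of roughly the modest size already seen at this position, a 1.9-fold lower number from compound 3 to compound 4 (0.28 log units; within the scatter). The estimate for compound 4 is 2.5 ug/mL, with a range from 1 ug/mL to 6 ug/mL.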

Compound 4, half-maximal inhibitory concentration: 26.1 ug/mL
Compound 4: middle estimate off by 10-fold (1.02 log units), on the low side, and the stated range ends below it.
By their numbers in this assay, from the lowest: compound 1; then compound 3; then compound 2; then compound 4.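

In this assay, putting 2,6-difluorophenyl on the carbonyl carbon gives a 5.4-fold higher number from compound 3 to compound 4 (0.74 log units; beyond the scatter) and also a 2.5-fold higher number from compound 2 to compound 4 (0.40 log units; beyond the scatter) on the shared core. With the earlier 2.2-fold lower number from compound 2 to compound 3 (0.34 log units; beyond the scatter) this sets the three groups at this position in a clear order, with 3-nitrophenyl giving the lowest number, 3-(trifluoromethyl)phenyl the middle one and 2,6-difluorophenyl the highest, so the group that entered is the poorest of the three here. Compound 1 adds a further lesson: with 2,6-difluorophenyl held fixed, trifluoromethyl in place of methyl on an aromatic carbon gives a 24-fold higher number from compound 1 to compound 4 (1.37 log units; beyond the scatter) and is the largest step in the set, so the low number of compound 1 cannot be credited to 2,6-difluorophenyl alone.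

Nothing shown gives a reason for any of these steps. As far as these compounds go, it also remains open whether 3-nitrophenyl would keep its lead over 2,6-difluorophenyl with methyl in place of trifluoromethyl on the aromatic carbon, and what a 3-aminophenyl group or a simple methyl group on the same carbonyl carbon would give.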